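Removing One Methoxy from the Ring on the Carbonyl

This account rests on a few compounds, and the source may have more. Where it says the series, first, only, none or still open, it means among the compounds named here.

Measured so far:
Compound 1, `COc1cc(-c2cc(/C=C/C(=O)c3ccc(N)cc3)[nH]n2)cc(OC)c1OC`: 1770 nM
Compound 2, `COc1cc(-c2cc(/C=C/C(=O)c3ccc(Cl)c(Cl)c3)[nH]n2)cc(OC)c1OC`: 1720 nM
Compound 3, `COc1ccc(C(=O)/C=C/c2cc(-c3cc(OC)c(OC)c(OC)c3)n[nH]2)cc1OC`: 1440 nM

These three compounds share the same core and differ only in the aromatic ring attached to the carbonyl carbon. In a functional assay on HOP-62 cells (Homo sapiens) for inhibition, read by sulforhodamine B assay, with a stated time of 48 h (a higher number here means a weaker inhibitor of growth, a lower number a stronger inhibitor of growth), compound 1 gives 1770 nM, compound 2 gives 1720 nM, and compound 3 gives 1440 nM. The three numbers are practically indistinguishable: the step of a 1.0-fold lower number from compound 1 to compound 2 (0.01 log units; within the scatter), the step of a 1.2-fold lower number from compound 1 to compound 3 (0.09 log units; within the scatter) and the step of a 1.2-fold lower number from compound 2 to compound 3 (0.08 log units; within the scatter) all fall within the scatter of repeat measurements. Compound 3 happens to carry the smallest number, but nothing separates it from the other two.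

Compound 4, `COc1ccc(C(=O)/C=C/c2cc(-c3cc(OC)c(OC)c(OC)c3)n[nH]2)cc1`, has not been measured. It differs from compound 3 in one place: hydrogen in place of methoxy on an aromatic carbon. For the measured compounds named here, no measured pair shows exactly this change. The measured steps instead swap the whole ring on the carbonyl carbon, including swapping 4-aminophenyl and 3,4-dichlorophenyl for 3,4-dimethoxyphenyl, and none of these swaps moved the number beyond the scatter. Since even these larger changes left the numbers where they were, only a small step, none beyond the scatter, is expected in this assay: a 1.1-fold higher number from compound 3 to compound 4 (0.05 log units; within the scatter). Compound 4 is therefore estimated to give 1600 nM, with a range from 700 nM to 3600 nM.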

Compound 4, concentration for 50% growth inhibition: 1760 nM
Compound 4: middle estimate off by 1.1-fold (0.04 log units), on the low side; low and high end bracket the measured number.
By their numbers in this assay, from the lowest: compounds 3, 2, 4 and 1 (each within the scatter of the next).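

The single-group change at this spot is now seen directly: going from 3,4-dimethoxyphenyl to 4-methoxyphenyl gives a 1.2-fold higher number from compound 3 to compound 4 (0.09 log units; within the scatter) in this assay, so this methoxy can be replaced by hydrogen without any change that stands clear of the scatter. For the compounds shown here, the earlier compounds showed only swaps of the whole ring, whereas this pair isolates one group on that ring, and the new compound also sits level with the other two, with a 1.0-fold higher number from compound 2 to compound 4 (0.01 log units; within the scatter) and a 1.0-fold lower number from compound 1 to compound 4 (0.00 log units; within the scatter), the latter being the single swap of methoxy for amino on an aromatic carbon. No measurement at hand offers an explanation for this flat result.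

Going by these compounds, all four rings on the carbonyl carbon give numbers within the scatter of one another, so it remains open whether a different group on this ring, such as a hydroxy group, a carboxylic acid or a longer chain like ethoxy, would shift the number beyond the scatter. Every compound shown also keeps the shared core unchanged, which leaves open how much the growth inhibition depends on that part rather than on the ring attached to the carbonyl.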